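The compounds below may be only part of what the source reports. "The series", "measured", "known", "first", "only" and "open" are said of these compounds alone.

Three compounds built on one shared core differ only in the saturated chain that hangs from a carbonyl. Compound 1 `CCCCCCCCCC(=O)Nc1nnc(S[C@@H]2O[C@H](CO)[C@H](O)[C@H](O)[C@H]2O)s1` gives 53100 nM in a functional assay on MDA-MB-231 cells (Homo sapiens) for cytotoxicity, read by MTT assay, with a stated time of 24 h; on this read-out lower numbers stand for stronger inhibition and higher numbers for weaker inhibition. Compound 2 `CCCCCC(=O)Nc1nnc(S[C@@H]2O[C@H](CO)[C@H](O)[C@H](O)[C@H]2O)s1` gives 28700 nM in this assay, and compound 3 `CCCCCCCCCCCCCC(=O)Nc1nnc(S[C@@H]2O[C@H](CO)[C@H](O)[C@H](O)[C@H]2O)s1` gives 33300 nM in this assay. On these three numbers compound 3 stands second highest, closest to compound 2 and furthest from compound 1, and all three lie within the scatter of one another. Compound 4 `CCCCCCCC/C=C\CCCCCCCCCCCC(=O)Nc1nnc(S[C@@H]2O[C@H](CO)[C@H](O)[C@H](O)[C@H]2O)s1` is the next variation: dec-1-en-1-yl in place of ethyl on a saturated chain carbon, ten or more bonds along the chain from a carbonyl carbon. The measured steps that bear on this change are those that lengthen or shorten the chain, namely a 1.9-fold lower number from compound 1 to compound 2 (0.27 log units; within the scatter), a 1.6-fold lower number from compound 1 to compound 3 (0.20 log units; within the scatter) and a 1.2-fold higher number from compound 2 to compound 3 (0.06 log units; within the scatter). None of them moved the number beyond the scatter. Among the measured compounds shown here, the chain of compound 4 reaches further out than any measured chain and carries a double bond, for which no measured step exists, yet the expectation from the chain steps is a 1.1-fold higher number from compound 3 to compound 4 (0.03 log units; within the scatter), that is, no step beyond the scatter. Compound 4 is therefore estimated at 36000 nM in this assay, with a range from 15000 nM to 85000 nM.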

Compound 4, half-maximal inhibitory concentration: 70400 nM
Compound 4: the middle estimate sits 2.0-fold (0.29 log units) below what was measured; measured number inside the range.
By their numbers in this assay, from the lowest: compounds 2, 3, 1 and 4 (each within the scatter of the next, the first and the last beyond it).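

In this assay, among the compounds shown here, putting dec-1-en-1-yl in place of ethyl on a saturated chain carbon gives a 2.1-fold higher number from compound 3 to compound 4 (0.33 log units; beyond the scatter), the first step to pass the scatter, though only by a modest margin. The other new step, a 1.3-fold higher number from compound 1 to compound 4 (0.12 log units; within the scatter), stays inside the scatter, so this long chain with its double bond is set apart from one shorter saturated chain but not from another. Nothing in the data shown gives a reason for this difference.

The step to compound 4 lengthens the chain and adds a double bond at once, so the two changes cannot be told apart here; a fully saturated chain of the same length as in compound 4 would separate them. Also open, as far as these compounds go, is what happens when the chain ends in something other than plain carbon and hydrogen, such as an amine or a carboxylic acid, and whether the same small differences would appear on other cell lines.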